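Swapping the aryl group on a triazole-linked hydroxamic acid

The source may report more compounds than this note shows. Statements on the series, on what has been measured and on what is new or still open speak of the compounds shown alone.

Among the measured compounds shown here, compound 2 `CC(C)c1ccc(-c2nc(CNc3ccc(C(=O)NO)cc3)n(-c3ccccc3)n2)cc1` stands lowest of the two numbers so far: in an assay on Sf9 cells for inhibition of protein deacetylase HDAC6 (Homo sapiens), read by fluorescence, with a stated time of 40 min, tested at 100 nM (on this read-out lower numbers stand for less inhibition and higher numbers for more inhibition at the one concentration tested (going by the name of the read-out)), compound 2 gives 27.6%. Its nearest neighbour is compound 1 `O=C(NO)c1ccc(NCc2nc(-c3ccccc3)nn2-c2ccccc2)cc1`, which in this assay gives 72.6%. For the measured compounds named here, the single measured step, a number 45 percentage points lower from compound 1 to compound 2 (beyond the scatter), is the only one in hand, and it is large and beyond the scatter.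

Compound 3 `O=C(NO)c1ccc(NCc2nc(-c3ccncc3)nn2-c2ccccc2)cc1` has not yet been measured. It differs from compound 2 in one place: pyridin-4-yl in place of 4-isopropylphenyl on an aromatic carbon. This change removes the isopropyl whose introduction marked the step from compound 1 to compound 2, and at the same time puts a pyridin-4-yl where compound 1 carries a phenyl. The measured step is therefore expected to be relevant mainly in reverse, with the remaining phenyl-to-pyridin-4-yl exchange untested here, so the direction is expected upward and the size large, as a number 37.4 percentage points higher from compound 2 to compound 3 (beyond the scatter). For compound 3 the estimated value in this assay is 65%, within a range from 40% to 85%.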

Compound 3, a percentage reported as inhibition, at one concentration (the size of the read-out at that concentration, not a potency): 30.8%
For compound 3 the middle estimate is 34.2 percentage points above the measured one, and the stated range ends above it.
By their numbers in this assay, from the lowest: compounds 2 and 3 (each within the scatter of the next); then compound 1.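

At this position, on an aromatic carbon between two ring nitrogen atoms, the result shows that the unsubstituted phenyl of compound 1 is sensitive to a change inside the ring as well as to added bulk: in this assay, pyridin-4-yl in place of phenyl gives a number 41.8 percentage points lower from compound 1 to compound 3 (beyond the scatter) and so costs about as much as the isopropyl did. Pyridin-4-yl in place of 4-isopropylphenyl gives a number 3.2 percentage points higher from compound 2 to compound 3 (within the scatter) and so leaves the two groups indistinguishable in this read-out, which means the low number of compound 2 can no longer be read as something peculiar to the isopropyl. Among these three compounds, both departures from phenyl lower the number and none goes against this, but no measurement offered here explains why.

From the compounds shown here alone, what stays open is whether any change to this phenyl has the same outcome, for instance a single fluorine or a methyl on the ring, or a pyridin-3-yl with its nitrogen placed elsewhere. A single concentration also leaves open how these numbers would translate into potency across a full concentration range.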